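A few compounds are considered here, and "the series" means these few. Any claim that something is new, unique, unknown or untested is made for them only; others in the source may bear on it.

In a functional assay on BaF3 cells (Mus musculus) for inhibition, read by CCK-8 assay, with a stated time of 72 h (on this read-out higher numbers stand for weaker inhibition of growth and lower numbers for stronger inhibition of growth), compound 1 (`Cc1ccc(NC(=O)Nc2ccc(Oc3cc(NCc4ccccc4)ncn3)cc2)cc1C(F)(F)F`) gives 3010 nM and compound 2 (`Cc1ccc(NC(=O)Nc2ccc(Oc3cc(N4CCNC[C@@H]4C)ncn3)cc2)cc1C(F)(F)F`) gives 8120 nM, while compound 3 (`CCC(=O)Nc1cc(Oc2ccc(NC(=O)Nc3ccc(C)c(C(F)(F)F)c3)cc2)ncn1`) gives 990 nM as the lowest of the three numbers. Compound 4 (`Cc1ccc(NC(=O)Nc2ccc(Oc3cc(NCCO)ncn3)cc2)cc1C(F)(F)F`) differs from compound 3 in one place (2-hydroxyethyl in place of propanoyl on a nitrogen on an aromatic ring), with 2-hydroxyethyl in place of propanoyl on a nitrogen on an aromatic ring. Within the data shown here, two measured steps bear on this: one on that same nitrogen (a 3.0-fold lower number from compound 1 to compound 3 (0.48 log units; beyond the scatter)), with propanoyl in place of benzyl, and another (an 8.2-fold lower number from compound 2 to compound 3 (0.91 log units; beyond the scatter)), with propanoylamino in place of 2-methylpiperazin-1-yl. Both are modest and both end at the lowest number. Among the measured compounds shown here, no measured compound carries 2-hydroxyethyl, so the loss of propanoyl is expected to bring only a modest rise. The expected change (a 2.5-fold higher number from compound 3 to compound 4 (0.40 log units; beyond the scatter)) is of that size. The estimate for compound 4 is 2500 nM within a range of 800 nM to 8000 nM on this evidence.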

Compound 4, concentration for 50% growth inhibition: > 10000 nM
Compound 4 ended at the assay's limit; the forecaster's own chance of this, stated with the estimate: 3%; middle value at least 4.0-fold (0.60 log units) from the limit.
By their numbers in this assay, from the lowest: compound 3; then compound 1; then compound 2. At a limit, above all of these: compound 4.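

Among these compounds, on this nitrogen, a saturated hydroxyl-bearing chain proved far less tolerated than the earlier steps suggested, with an at least 10-fold higher number from compound 3 to compound 4 (1.00 log units; beyond the scatter) for 2-hydroxyethyl in place of propanoyl and an at least 3.3-fold higher number from compound 1 to compound 4 (0.52 log units; beyond the scatter) for hydroxymethyl in place of phenyl on the chain. The comparison with the 2-methylpiperazin-1-yl compound gives an at least 1.2-fold higher number from compound 2 to compound 4 (0.09 log units; that floor lies within the scatter) and so sets no order between them. Compound 4 stands at a limit of the assay, not at a number: the limit of > 10000 nM in this assay, at which 1 of the 4 values shown sits.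

The compounds shown leave open whether the propanoyl carbonyl or the terminal hydroxyl governs this loss. A 2-methoxyethyl group, an acetyl group or a longer acyl chain on this nitrogen could separate the two.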